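The compounds below may be only part of what the source reports. "The series", "measured", "known", "first", "only" and "open" are said of these compounds alone.

Measured so far in an ADME assay on the whole organism with Oryza sativa as the target, tested at 0.1 uM; a lower number here means a stronger effect, a higher number a weaker effect of the compound at the concentration tested:
compound 1 `Cc1ccc(NC(=O)N[C@H](C)c2ccccc2)cc1`, 100%
compound 2 `Cc1ccc(NC(=O)N[C@@H](C)c2ccccc2)cc1`, 100%
compound 3 `C[C@H](NC(=O)Nc1ccccc1C(C)(C)C)c1ccccc1`, 101%

Compound 1 stands level with compound 2, and compound 3 lies within the scatter of both; all three numbers sit at the same level. Within the data shown here, the one measured step, no change at the digits printed from compound 1 to compound 2 (within the scatter), rests on the fact that compounds 1 and 2 differ only in the configuration as drawn and shows no movement. The unmeasured compound 4 `C[C@@H](NC(=O)Nc1ccc(C(F)(F)F)cc1)c1ccccc1` differs from compound 1 by trifluoromethyl in place of methyl on an aromatic carbon. Among the measured compounds shown here, none of the measured steps bears on this exchange: the only one concerns configuration alone, not a substituent on the aromatic ring. For the measured compounds named here, with every measured number at one level and no step moving beyond the scatter, the step of no change at the digits printed from compound 1 to compound 4 (within the scatter) is expected to stay within the scatter. Compound 4 is therefore expected to give 100% in this assay, in the range 90% to 110%.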

Compound 4, a percentage reported as activity, at one concentration (the size of the read-out at that concentration, not a potency): 93%
The estimate for compound 4 lay 7 percentage points above the measured number, and the stated range covers the measured number.
By their numbers in this assay, from the lowest: compounds 4, 1, 2 and 3 (each within the scatter of the next).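

In this assay, trifluoromethyl in place of methyl on an aromatic carbon, para to a large group, gives a number 7 percentage points lower from compound 1 to compound 4 (within the scatter). The earlier step covered configuration alone, whereas this one shows that a substituent exchange at this position also stays within the scatter. No available evidence bears on this exchange.

As far as these compounds go, whether an amine, a carboxylic acid or a nitrile at this position would stay within the scatter remains open. The compounds shown also leave open whether any change moves this assay beyond the scatter.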